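The source may hold more compounds than are shown below. What is called first, only, known or untested is meant among the compounds shown, and "the series" means these compounds.

Measured in an ADME assay on L6 cells (Rattus norvegicus) for cytotoxicity; on this read-out lower numbers stand for stronger inhibition and higher numbers for weaker inhibition:
- compound 1 `CCN(CC)CCC(=O)OC1CC2(N3CCCC3)CC(c3ccccc3)C1C(c1ccccc1)C2`: 19200 nM
- compound 2 `O=C(CCN1CCCCC1)OC1CC2(N3CCCC3)CC(c3ccccc3)C1C(c1ccccc1)C2`: 17800 nM

Compound 2 gives 17800 nM and compound 1 gives 19200 nM, so the two cannot be told apart on this read-out. The next compound is compound 3 `O=C(CCN1CCC(O)CC1)OC1CC2(N3CCCC3)CC(c3ccccc3)C1C(c1ccccc1)C2`, which differs from compound 2 as follows: hydroxy in place of hydrogen on a saturated ring carbon. In words, it has hydroxy in place of hydrogen on a saturated ring carbon, so that piperidin-1-yl becomes 4-hydroxypiperidin-1-yl.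

Among the measured compounds shown here, only one measured step bears on this change. It is a 1.1-fold lower number from compound 1 to compound 2 (0.03 log units; within the scatter), and it lies within the scatter. That step replaces diethylamino with piperidin-1-yl at the same end of the chain, but neither of its compounds carries a hydroxy group, so the data give no direction for the new change. With that single step as the guide, no shift beyond the scatter is expected in this assay, and the range is left wide on both sides. The expected step is a 1.1-fold higher number from compound 2 to compound 3 (0.05 log units; within the scatter). For compound 3 the estimated value is 20000 nM, with an expected range of 9000 nM to 45000 nM.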

Compound 3, half-maximal inhibitory concentration: 35600 nM
Compound 3: the middle estimate sits 1.8-fold (0.25 log units) below what was measured, within the range that was stated.
By their numbers in this assay, from the lowest: compounds 2, 1 and 3 (each within the scatter of the next).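

In this assay the hydroxy group on the saturated ring carbon, three ring bonds from the ring nitrogen, gives a 2.0-fold higher number from compound 2 to compound 3 (0.30 log units; within the scatter) and so leaves 4-hydroxypiperidin-1-yl not separable from piperidin-1-yl on this read-out. Among the compounds shown here, the earlier pair had only exchanged one amine end for another, whereas this is the first change made on the piperidine ring itself, and the comparison with the diethylamino end reads the same way, as a 1.9-fold higher number from compound 1 to compound 3 (0.27 log units; within the scatter). All three compounds therefore stay within the scatter of one another, and the data offer no measured reason for the size of either new step.

The compounds shown leave open whether a methoxy group, an amine or a carboxylic acid on the same ring carbon would move the number beyond the scatter, or whether this ring carbon tolerates such groups as it does hydroxy. They also leave open whether a longer chain between the carbonyl and the 4-hydroxypiperidin-1-yl end would give a number that differs from those of compound 2 and compound 3.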